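Two methoxy groups for a methyl on the aryl ring

A few compounds are considered here, and "the series" means these few. Any claim that something is new, unique, unknown or untested is made for them only; others in the source may bear on it.

Compound 2 `Cc1ccc(-c2nc(CN3CCC(C(=O)NCCCN4C[C@H](C)C[C@H](C)C4)CC3)c(C)o2)cc1` has been tested in a physicochemical assay for solubility, in phosphate buffer, measured as kinetic solubility, at pH 7.4; a lower number here means a less soluble compound, a higher number a more soluble compound. In this assay compound 2 gives > 69 ug/mL, which is a limit of the measurement rather than a number. Compound 1 `Cc1oc(-c2c(Cl)cccc2Br)nc1CN1CCC(C(=O)NCCCN2C[C@H](C)C[C@H](C)C2)CC1` likewise reaches a limit, giving > 83 ug/mL. For the measured compounds named here, the only measured step, a step that the two limits leave unreadable from compound 1 to compound 2, therefore cannot be read. Compound 3 `COc1ccc(-c2nc(CN3CCC(C(=O)NCCCN4C[C@H](C)C[C@H](C)C4)CC3)c(C)o2)cc1OC` differs from compound 2 by 3,4-dimethoxyphenyl in place of 4-methylphenyl on an aromatic carbon. No readable step bears on this change, so no shift beyond the scatter is expected. Compound 3 is estimated at 80 ug/mL, with a range from 35 ug/mL to 180 ug/mL, an expected step that the limit leaves unreadable from compound 2 to compound 3.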

Compound 3, solubility: > 76 ug/mL
Compound 3 ended at the assay's limit; the forecaster's own chance of this, stated with the estimate: 65%; the middle value does not contradict the limit.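

For the compounds shown here, compound 1, compound 2 and compound 3 all stand at limits in this assay, so no step between them can be read. The compounds shown leave open whether their true values differ at all.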